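The source may hold more compounds than are shown below. What is called first, only, known or untested is meant among the compounds shown, and "the series" means these compounds.

Measured compounds:
compound 1 `C#CCOc1ccc(-c2cc(-c3ccc(OCC#C)c(OCC)c3)nc(-c3ccccc3)n2)cc1`, 29000 nM in an assay on BTI-TN-5B1-4 cells for inhibition of Amine oxidase [flavin-containing] B (Homo sapiens), read by fluorescence and Amplex Red, using microsomes, with a stated time of 30 min; a lower number here means a stronger inhibitor, a higher number a weaker inhibitor
compound 2 `C#CCOc1ccc(-c2cc(-c3ccccc3OCC#C)nc(C)n2)cc1`, 18100 nM
compound 3 `C#CCOc1ccc(-c2cc(-c3ccc(OCC#C)c(OCC)c3)nc(C)n2)cc1`, 11000 nM

Three compounds with a shared core carry propargyloxy groups on their aryl arms. Compound 3 and compound 1 differ by phenyl in place of methyl on an aromatic carbon. That step gives a 2.6-fold higher number from compound 3 to compound 1 (0.42 log units; beyond the scatter). Compound 2 stands between the other two values, within the scatter of each, so no order among them is claimed. How the core of compound 2 differs from that of compound 3 is not broken down here.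

Compound 4 `C#CCOc1ccc(-c2cc(-c3ccccc3OCC#C)nc(-c3ccccc3)n2)cc1` is not yet measured. It relates to compound 2 by phenyl in place of methyl on an aromatic carbon. The surroundings of the place are not identical to those in the earlier pair, which is described as meta to a 4-(propargyloxy)phenyl group and meta to a large group, whereas here the place is meta to two large groups; the change is therefore the same kind of change, not the same. Because the earlier step gave a 2.6-fold higher number from compound 3 to compound 1 (0.42 log units; beyond the scatter), compound 4 is expected to show a comparable step, a 2.6-fold higher number from compound 2 to compound 4 (0.41 log units; beyond the scatter), in this assay. On that basis compound 4 is estimated at 47000 nM, with a range from 24000 nM to 95000 nM.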

Compound 4, half-maximal inhibitory concentration: 14400 nM
The estimate for compound 4 lay 3.3-fold (0.51 log units) above the measured number; measured number below the stated range.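

In this assay, phenyl in place of methyl on an aromatic carbon gives a 1.3-fold lower number from compound 2 to compound 4 (0.10 log units; within the scatter), so on this core the change has no readable effect on the number. Set beside the step on the other core, the same change does not carry over as a fixed increment, and a step read on one core is a poor guide to the other: the same change on two cores in this assay, a 2.6-fold higher number (0.42 log units; beyond the scatter) from compound 3 to compound 1 and a 1.3-fold lower number (0.10 log units; within the scatter) from compound 2 to compound 4, 3.3-fold (0.52 log units) apart, beyond the scatter of two such steps

This shows that the outcome of the change depends on the core in these two pairs, but it does not show which feature of the cores accounts for the gap, and two pairs give no rule for any further core.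

As far as these compounds go, at the place between two ring nitrogen atoms, only methyl and phenyl appear, so it stays open whether an amine, a carboxylic acid or a longer alkyl chain there would follow either step. Also open, from the compounds shown here alone, is whether a third core carrying the same methyl and phenyl pair would side with compound 1 and compound 3 or with compound 2 and compound 4.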